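Trifluoromethyl for Chloro in a Cytotoxicity Series

The compounds below may be only part of what the source reports. "The series", "measured", "known", "first", "only" and "open" are said of these compounds alone.

Measured compounds:
Compound 1, `O=C1C(=O)N(CN2CCN(c3ccnc4cc(Cl)ccc34)CC2)c2cccc(Br)c21`: 65600 nM
Compound 2, `O=C1C(=O)N(CN2CCN(c3ccnc4cc(C(F)(F)F)ccc34)CC2)c2cccc(Br)c21`: 37900 nM
Compound 3, `NC(=S)N/N=C1/C(=O)N(CN2CCN(c3ccnc4cc(Cl)ccc34)CC2)c2cccc(Cl)c21`: 19800 nM

All three were tested in an ADME assay on MCF-10A cells (Homo sapiens) for cytotoxicity, read by sulforhodamine B assay, with a stated time of 48 h; on this read-out higher numbers stand for weaker inhibition of growth and lower numbers for stronger inhibition of growth. Compound 1 and compound 2 share a core and differ in one place: trifluoromethyl in place of chloro on an aromatic carbon. This change gave a 1.7-fold lower number from compound 1 to compound 2 (0.24 log units; within the scatter). Compound 3 carries a different core; the difference between the two cores is not broken down here. Compound 4, `NC(=S)N/N=C1/C(=O)N(CN2CCN(c3ccnc4cc(C(F)(F)F)ccc34)CC2)c2cccc(Cl)c21`, has not yet been measured in this assay. It differs from compound 3 in one place: trifluoromethyl in place of chloro on an aromatic carbon, which is the same change, at the same place, as that made between compound 1 and compound 2. Resting on the one measured instance, which gave a 1.7-fold lower number from compound 1 to compound 2 (0.24 log units; within the scatter), the expected step for compound 4 is a 1.7-fold lower number from compound 3 to compound 4 (0.22 log units; within the scatter). Compound 4 is therefore estimated at 12000 nM, with a likely range from 4000 nM to 35000 nM.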

Compound 4, concentration for 50% growth inhibition: 51700 nM
Compound 4: the middle estimate sits 4.3-fold (0.63 log units) below what was measured; the whole stated range lies below it.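

In this assay, trifluoromethyl in place of chloro gave a 2.6-fold higher number from compound 3 to compound 4 (0.42 log units; beyond the scatter), so the step seen on the first core did not carry over to the second: the same change on two cores in this assay, a 1.7-fold lower number (0.24 log units; within the scatter) from compound 1 to compound 2 and a 2.6-fold higher number (0.42 log units; beyond the scatter) from compound 3 to compound 4, 4.5-fold (0.66 log units) apart, beyond the scatter of two such steps. In this series, then, the step measured on one core is not a reliable guide to the same change on the other. Within the data shown here, it does not show which difference between the cores goes with the gap, since they differ in more than one place and each core offers only a single pair.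

The compounds shown carry only chloro and trifluoromethyl at this place, so it remains open how a nitrile or a methoxy group there would fare on either core. Also open, going by these compounds, is whether a core differing from either one in a single place would give the step of compound 1 and compound 2 or that of compound 3 and compound 4.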